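The compounds below may be only part of what the source reports. "The series", "measured", "known", "first", "only" and "open" are said of these compounds alone.

Measured in a physicochemical assay for metabolic stability, read by LC-MS, in simulated gastric fluid, with a stated time of 15 min, tested at 50 uM; on this read-out higher numbers stand for a more stable compound and lower numbers for a less stable compound:
compound 1 `CCC(=O)c1ccccc1OC(=O)c1coc(-c2ccccc2)n1`: 1.8%
compound 2 `CCCc1ccccc1OC(=O)c1coc(-c2ccccc2)n1`: 0.9%

Compound 2, at 0.9%, lies within the scatter of compound 1, at 1.8%. Compound 3 `CC(C)(C)c1ccccc1OC(=O)c1coc(-c2ccccc2)n1` carries tert-butyl in place of propyl on an aromatic carbon, ortho to a large group: tert-butyl in place of propyl on an aromatic carbon. Among the measured compounds shown here, one measured step bears on this change, a number 0.9 percentage points lower from compound 1 to compound 2 (within the scatter), and it replaces a different group at the same place. For the measured compounds named here, with only that step to go on, no shift beyond the scatter is expected in this assay. The expected step is a number 2.1 percentage points higher from compound 2 to compound 3 (within the scatter). For compound 3 the estimate is 3%, with an expected range of 0.5% to 12%.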

Compound 3, percent of the compound remaining: 0.7%
Compound 3: the middle estimate sits 2.3 percentage points above what was measured; the range from low to high includes it.
By their numbers in this assay, from the lowest: compounds 3, 2 and 1 (each within the scatter of the next).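

In this assay tert-butyl on this aromatic carbon, ortho to a large group, gives a number 0.2 percentage points lower from compound 2 to compound 3 (within the scatter) and a number 1.1 percentage points lower from compound 1 to compound 3 (within the scatter) as its steps from propyl and propanoyl, so all three groups lie within the scatter of one another. At this position, a branched carbon chain therefore shows no separation from a straight one or from a ketone-bearing one on this read-out. No measurement here bears on the reason for this result.

Open, from the compounds shown here alone, is whether an amine or a carboxylic acid on this aromatic carbon would move the read-out beyond the scatter. Also open, going by these compounds, is whether an amide in place of the ester would do so.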